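A few compounds are considered here, and "the series" means these few. Any claim that something is new, unique, unknown or untested is made for them only; others in the source may bear on it.

Compound 1 `Cn1c(=O)c(-c2c(Br)cccc2Br)cc2c(N)nc(Nc3ccccc3)nc21`: 800 nM
Compound 2 `Nc1nc(Nc2ccccc2)nc2[nH]c(=O)c(-c3ccccc3)cc12`: 13800 nM

In an ADME assay on Huh-7 cells (Homo sapiens) for cytotoxicity, read by MTT assay, with a stated time of 4 h, at 37 degrees C (on this read-out lower numbers stand for higher toxicity in this test and higher numbers for lower toxicity in this test), compound 2 stands highest of the two at 13800 nM, well clear of compound 1 at 800 nM. Compound 3 `Cn1c(=O)c(-c2ccccc2)cc2c(N)nc(Nc3ccccc3)nc21` differs from compound 2 by methyl in place of hydrogen on an aromatic nitrogen. Among the compounds with values here, no measured pair shows this change alone. Within the data shown here, the only lean towards lower numbers comes from compound 1 at 800 nM, so a small downward move is expected, roughly within the scatter. The expected move is a 1.7-fold lower number from compound 2 to compound 3 (0.24 log units; within the scatter). For compound 3 the estimated value is 8000 nM, with an expected range of 3000 nM to 20000 nM.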

Compound 3, half-maximal cytotoxic concentration: 23500 nM
The estimate for compound 3 lay 2.9-fold (0.47 log units) below the measured number; measured number outside the range, above it.
By their numbers in this assay, from the lowest: compound 1; then compounds 2 and 3 (each within the scatter of the next).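

In this assay methyl in place of hydrogen on an aromatic nitrogen gives a 1.7-fold higher number from compound 2 to compound 3 (0.23 log units; within the scatter) and so leaves this position without a change beyond the scatter. With that methyl present in both compounds, phenyl in place of 2,6-dibromophenyl on an aromatic carbon gives a 29-fold higher number from compound 1 to compound 3 (1.47 log units; beyond the scatter) as the large step among these compounds. No measurement on hand explains either step.

Open, as far as these compounds go, is whether an ethyl group or a longer chain on that nitrogen also stays within the scatter. Also open, from the compounds shown here alone, is whether a single bromine, or chlorine in place of bromine, on the phenyl group gives a step of similar size.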